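Butyl for furan-2-yl on a carbonyl carbon

A few compounds are considered here, and "the series" means these few. Any claim that something is new, unique, unknown or untested is made for them only; others in the source may bear on it.

Compound 1 `C=C1CC[C@@H]2[C@](C)(COC(=O)c3ccco3)[C@H](O)CC[C@@]2(C)[C@@H]1/C=C/C1=CCOC1=O` gives 92000 nM
Compound 2 `C=C1CC[C@@H]2[C@](C)(COC(=O)c3cccs3)[C@H](OC(=O)c3cccs3)CC[C@@]2(C)[C@@H]1/C=C/C1=CCOC1=O` gives > 1530000 nM (a limit)
Compound 3 `C=C1CC[C@@H]2[C@](C)(COC(=O)c3ccco3)[C@H](O)CC[C@@]2(C)[C@@H]1C/C=C1\C=COC1=O` gives > 2150000 nM (a limit)

All three were tested in an ADME assay on HepG2 2.2.15 cells (Homo sapiens) for cytotoxicity, read by MTT assay; on this read-out lower numbers stand for higher toxicity in this test and higher numbers for lower toxicity in this test. Compound 3 stands at > 2150000 nM, which is a limit and not a number. Compound 4 `C=C1CC[C@@H]2[C@](C)(COC(=O)CCCC)[C@H](O)CC[C@@]2(C)[C@@H]1C/C=C1\C=COC1=O` differs from it by butyl in place of furan-2-yl on a carbonyl carbon. Within the data shown here, the one measured step, an at least 23-fold higher number from compound 1 to compound 3 (1.36 log units; beyond the scatter), is large, but it changes another part and leaves furan-2-yl in place. Among the measured compounds shown here, no measured step covers this swap. Compound 4 keeps the outcome of that large step, so it is expected to stay high in this assay, with no change beyond the scatter. The expected step is an at least 1.4-fold lower number from compound 3 to compound 4 (0.15 log units; that floor lies within the scatter). For compound 4 the estimated value is 1500000 nM, with an expected range of 400000 nM to 3500000 nM.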

Compound 4, half-maximal cytotoxic concentration: 225000 nM
The estimate for compound 4 lay 6.7-fold (0.82 log units) above the measured number; the whole stated range lies above it.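

Replacing furan-2-yl with butyl on this carbonyl carbon does matter in this assay: the swap gives an at least 9.5-fold lower number from compound 3 to compound 4 (0.98 log units; beyond the scatter), so the butyl compound shows higher toxicity in this test. The earlier compounds shown here never varied this group on its own. Only a floor is known for the size of this step because the value for compound 3 is a limit: the limit of > 2150000 nM in this assay, at which 1 of the 4 values shown sits.

Going by these compounds, whether a longer chain or a phenyl ring here would move the number further remains open. So does whether butyl would have the same effect on compound 1.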